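A benzylamine swap on a diaminoquinoxaline growth inhibitor

The source may hold more compounds than are shown below. What is called first, only, known or untested is meant among the compounds shown, and "the series" means these compounds.

Among the compounds with values here, compound 1 `Nc1cc(N)c2nc(-c3ccccc3)c(NCc3ccc(Cl)c(Cl)c3)nc2c1` is the only member of this small set with a definite number in a functional assay on SF-295 cells (Homo sapiens) for inhibition, read by sulforhodamine B assay, with a stated time of 48 h (on this read-out higher numbers stand for weaker inhibition of growth and lower numbers for stronger inhibition of growth), where compound 1 gives 37200 nM. Compound 2 `CCOC(=O)[C@H](CCC(=O)O)NC(=O)c1ccc(Sc2nc3cc(N)cc(N)c3nc2-c2ccccc2)cc1` is reported in this assay only as a limit, < 100000 nM. Compound 3 `CCOC(=O)[C@H](CCC(=O)O)NC(=O)c1ccc(Oc2nc3cc(N)cc(N)c3nc2-c2ccccc2)cc1` likewise reaches only the limit of this assay, < 100000 nM. Against that background compound 1 stands alone as the sole measured value, and the limit of < 100000 nM in this assay, at which 2 of the 3 values shown sit, describes the rest.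

Compound 4 `COc1ccc(CNc2nc3cc(N)cc(N)c3nc2-c2ccccc2)cc1` keeps the shared core of compound 1 and differs in one place: 4-methoxyphenyl in place of 3,4-dichlorophenyl on a saturated chain carbon bound to a nitrogen on an aromatic ring, that is, 3,4-dichlorobenzyl to 4-methoxybenzyl. Within the data shown here, no measured pair in the set follows this kind of change, so there is no directly observed step to lean on. The expectation for compound 4 is therefore a step from compound 1 of about a 1.2-fold higher number from compound 1 to compound 4 (0.08 log units; within the scatter), essentially none beyond the scatter, with a fair chance that the assay returns only a limit. On this basis compound 4 is estimated at 45000 nM, with a range from 15000 nM to 100000 nM.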

Compound 4, concentration for total growth inhibition: 32400 nM
The estimate for compound 4 lay 1.4-fold (0.14 log units) above the measured number; measured number inside the range.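

In this assay the exchange of 3,4-dichlorobenzyl for 4-methoxybenzyl comes out as a 1.1-fold lower number from compound 1 to compound 4 (0.06 log units; within the scatter), so this place on the shared core holds either group with no difference beyond the scatter. The exchange removes both chlorine atoms and brings in an oxygen and a hydrogen-bond acceptor, yet the read-out does not separate the two groups. Compound 2 and compound 3 remain at a limit of the assay rather than a number: the limit of < 100000 nM in this assay, at which 2 of the 4 values shown sit.

The steps to those two limit values cannot be read, so the thioether and ether compounds say nothing about the benzylamine swap. Going by these compounds, whether an unsubstituted benzyl group, a benzyl group carrying an amine or a carboxylic acid, or a longer chain such as phenethyl would move the number beyond the scatter remains open.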